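This account rests on a few compounds, and the source may have more. Where it says the series, first, only, none or still open, it means among the compounds named here.

Working notes on the series. Of the compounds shown here, two have numbers so far. Compound 1 `C/C(=C\CN1CCCCC1)c1ccc(-c2ccccc2)cc1` in an assay on cell membranes for displacement of a labelled ligand from Sigma non-opioid intracellular receptor 1 (Cavia porcellus), read by scintillation counting, with a stated time of 150 min (on this read-out higher numbers stand for weaker inhibition and lower numbers for stronger inhibition), gives 0.86 nM. Compound 2 `COc1ccc(/C(C)=C/CN2CCC(Cc3ccccc3)CC2)cc1` in this assay gives 4.14 nM, the higher of the two numbers; compound 1 sits at the lower one, and the two structures differ in more than one place, so the two values are simply set side by side without a single step between them.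

Compound 3 `COc1ccc(/C(C)=C/CN2CCCCC2)cc1` is not yet measured. It is reached from compound 2 by one change, (hydrogen in place of benzyl on a saturated ring carbon), that is, hydrogen in place of benzyl on a saturated ring carbon. Among the measured compounds shown here, no measured pair shows this change, so its size is open. The expectation is a modest move toward a higher number, near the edge of the scatter, as a 1.4-fold higher number from compound 2 to compound 3 (0.16 log units; within the scatter). Compound 3 is therefore expected in this assay at about 6 nM, with a range from 1.5 nM to 25 nM.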

Compound 3, inhibition constant: 14 nM
Compound 3: the middle estimate sits 2.3-fold (0.37 log units) below what was measured, and the stated range covers the measured number.
By their numbers in this assay, from the lowest: compound 1; then compound 2; then compound 3.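

In this assay, among the compounds shown here, hydrogen in place of benzyl on the saturated ring carbon gives the first single-change reading at this position (a 3.4-fold higher number from compound 2 to compound 3 (0.53 log units; beyond the scatter)), so the benzyl group counts for a modest part of the number here. Methoxy in place of phenyl on the aromatic carbon gives a step printed as large (a 16-fold higher number from compound 1 to compound 3 (1.21 log units; beyond the scatter)), and compound 3 now joins compound 1 and compound 2 through one change each. The data shown give no measured reason for either step.
Open, from the compounds shown here alone, is whether methyl or phenyl on that saturated ring carbon would fall nearer compound 2 or compound 3, and whether the benzyl step keeps its size with phenyl rather than methoxy on the aromatic carbon. Also open, going by these compounds, is what a hydroxyl or a fluorine on that aromatic carbon would give.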